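The compounds below may be only part of what the source reports. "The series", "measured", "known", "first", "only" and "open" are said of these compounds alone.

Compound 1 `CC1=CC[C@H](C(C)(C)NC(=S)N/N=C/c2ccccc2O)CC1` is one of three thiosemicarbazones measured in a functional assay on PC-3 cells (Homo sapiens) for inhibition, read by sulforhodamine B assay, with a stated time of 48 h; a higher number here means a weaker inhibitor of growth, a lower number a stronger inhibitor of growth. Compound 1 gives < 40 nM, which is a limit of this assay rather than a number, so its standing among the three is known only as a boundary (the limit of < 40 nM in this assay, at which 1 of the 3 values shown sits). Compound 2 `COc1cc(/C=N/NC(=S)NC(C)(C)[C@H]2CC=C(C)CC2)ccc1O` gives 300 nM in this assay. Compound 3 `CC1=CC[C@H](C(C)(C)NC(=S)N/N=C/c2ccccc2[N+](=O)[O-])CC1`, carrying a nitro group in place of the hydroxy group, gives 1700 nM, and the step of an at least 42-fold higher number from compound 1 to compound 3 (1.62 log units; beyond the scatter) shows how much that single change costs.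

Compound 4 `CC1=CC[C@H](C(C)(C)NC(=S)N/N=C/c2ccco2)CC1` has not yet been measured. It differs from compound 1 in one place: furan-2-yl in place of 2-hydroxyphenyl on a carbon with a double bond to nitrogen. Within the data shown here, the only measured step that bears on this change, an at least 42-fold higher number from compound 1 to compound 3 (1.62 log units; beyond the scatter), was large and removed the hydroxy group, as this change also does. Compound 4 is therefore expected to show a higher number in this assay, with the step of an at least 12-fold higher number from compound 1 to compound 4 (1.09 log units; beyond the scatter) estimated in that direction. The estimate for compound 4 is 500 nM, with a range from 100 nM to 3000 nM.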

Compound 4, concentration for 50% growth inhibition: 13500 nM
Estimate against measurement, compound 4: 27-fold (1.43 log units) below; measured number above the stated range.
By their numbers in this assay, from the lowest: compound 2; then compound 3; then compound 4. At a limit, below all of these: compound 1.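

At this place, on a carbon with a double bond to nitrogen, furan-2-yl in place of 2-hydroxyphenyl gives an at least 330-fold higher number from compound 1 to compound 4 (2.52 log units; beyond the scatter) in this assay, so this five-membered aromatic ring does not stand in for the six-membered one. Compound 3 also lacks the hydroxy group and gives 1700 nM, while compound 4 gives 13500 nM, so the group that replaces the 2-hydroxyphenyl matters as well as the loss of the hydroxy group. The value of compound 1 is a limit, so this step is a bound and not an exact size: the limit of < 40 nM in this assay, at which 1 of the 4 values shown sits.

The compounds shown leave open how a phenyl ring carrying an amine or a carboxylic acid in place of the hydroxy group would read in this assay. They also leave open whether a furan ring bearing a hydroxy group would recover any of the loss.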